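The compounds below may be only part of what the source reports. "The series", "measured", "known", "first", "only" and "open" are said of these compounds alone.

Compound 1 `O=c1ccc2cc(OCc3cn(-c4cccc(CO)c4)nn3)ccc2o1` was run in a functional assay on A549 cells (Homo sapiens) for cytotoxicity, read by MTT assay, with a stated time of 48 h (on this read-out higher numbers stand for weaker inhibition and lower numbers for stronger inhibition), where compound 1 gives 35100 nM. Compound 2 `O=c1ccc2cc(OCc3cn(-c4cccc([N+](=O)[O-])c4)nn3)ccc2o1` shares the core of compound 1 but carries a 3-nitrophenyl group on an aromatic nitrogen; for compound 2 the result in this assay is "not determined" (no result reported), so there is no single number to place it on. Compound 3 `N#Cc1ccccc1-n1cc(COc2ccc3oc(=O)ccc3c2)nn1` differs from compound 2 by 2-cyanophenyl in place of 3-nitrophenyl on an aromatic nitrogen. Going by the values given here, with no measured step of this kind to lean on, only a change no larger than the usual scatter, in either direction, can be anticipated, and compound 3 is expected to give about 30000 nM, within 8000 nM to 120000 nM.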

Compound 3, half-maximal inhibitory concentration: 12600 nM
Beside the measured number, compound 3's estimate is 2.4-fold (0.38 log units) above it; low and high end bracket the measured number.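

Placing 2-cyanophenyl in place of 3-(hydroxymethyl)phenyl on the aromatic nitrogen gives a 2.8-fold lower number from compound 1 to compound 3 (0.44 log units; beyond the scatter) in this assay and provides the first readable step at this position. It shows that the number responds to the aryl group held there, modestly but beyond the usual scatter. Nothing available accounts for this shift. The step alters both the substituent and its place on the phenyl ring, so their shares cannot be separated. Going by these compounds, how 3-cyanophenyl or an aminophenyl group would compare remains open.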